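The compounds below may be only part of what the source reports. "The series", "measured", "known", "first", "only" and "open" are said of these compounds alone.

In a functional assay on MCF7 cells (Homo sapiens) for inhibition, read by MTT assay, with a stated time of 72 h (a higher number here means a weaker inhibitor, a lower number a stronger inhibitor), three close relatives of one series have been measured. Compound 1, `COc1cc2c(Oc3ccc(NC(=O)c4nn(-c5ccccc5)cc(C)c4=O)cc3F)ccnc2cc1OCCCCCC(=O)NO`, gives 2330 nM. Within the data shown here, compound 2, `COc1cc2c(Oc3ccc(NC(=O)c4nn(-c5ccccc5F)cc(C)c4=O)cc3F)ccnc2cc1OCCCCCC(=O)NO`, gives 2320 nM; the only measured single-point step, a 1.0-fold lower number from compound 1 to compound 2 (0.00 log units; within the scatter), changes nothing beyond the scatter. Compound 3, `COc1cc2c(Oc3ccc(NC(=O)c4nn(-c5cccc(C)c5)cc(C)c4=O)cc3)ccnc2cc1OCCCCCCC(=O)NO`, gives 1680 nM, the lowest of the three numbers, though both other values lie within the scatter of it, so no ordering can be read from them.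

Compound 4, `COc1cc2c(Oc3ccc(NC(=O)c4nn(-c5ccccc5C)cc(C)c4=O)cc3)ccnc2cc1OCCCCCCC(=O)NO`, differs from compound 3 in one place: 2-methylphenyl in place of 3-methylphenyl on an aromatic nitrogen.

Among the measured compounds shown here, the one measured step bears on this only loosely: it also alters the phenyl ring on the aromatic nitrogen, and it was flat. For the measured compounds named here, no measured pair shows a methyl moved around that ring. With nothing pointing either way, compound 4 is expected to sit close to compound 3, with the step of a 1.1-fold higher number from compound 3 to compound 4 (0.03 log units; within the scatter) expected to stay within the scatter. Compound 4 is therefore estimated at 1800 nM, with a likely range from 800 nM to 4000 nM.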

Compound 4, half-maximal inhibitory concentration: 1830 nM
For compound 4 the middle estimate is 1.0-fold (0.01 log units) below the measured one; measured number inside the range.
By their numbers in this assay, from the lowest: compounds 3, 4, 2 and 1 (each within the scatter of the next).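

Moving the methyl around the phenyl ring on the aromatic nitrogen, with 2-methylphenyl in place of 3-methylphenyl, gives a 1.1-fold higher number from compound 3 to compound 4 (0.04 log units; within the scatter) in this assay. The earlier step showed only that a fluoro on this ring left the number within the scatter; this pair adds that relocating a methyl, with the same atoms joined differently, also does so, at least between these two places on the ring. Nothing available explains this result.

From the compounds shown here alone, whether an amine, a carboxylic acid or a trifluoromethyl on this ring would take the number beyond the scatter remains open. So does whether a pyridine or a plain alkyl chain in place of the phenyl ring on the aromatic nitrogen would do so.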